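The source may report more compounds than this note shows. Statements on the series, on what has been measured and on what is new or still open speak of the compounds shown alone.

In an assay on HEK293 cells for inhibition of prostaglandin E2 receptor EP2 subtype (Rattus norvegicus) (on this read-out higher numbers stand for weaker inhibition and lower numbers for stronger inhibition), compound 1 `CCCCc1ccc(CN(c2ccccc2CCCC(=O)O)S(C)(=O)=O)cc1` gives 494 nM, compound 2 `CC(C)(C)c1ccc(CN(Cc2cccc(CCC(=O)O)c2)S(=O)(=O)c2ccccc2)cc1` gives 278 nM, and compound 3 `CC(C)(C)c1ccc(CN(Cc2cccc(OCC(=O)O)c2)S(C)(=O)=O)cc1` gives 792 nM. Among these three numbers compound 2 has the lowest; its gap to compound 1 lies within the scatter, so the two cannot be told apart, while the gap to compound 3 lies beyond it. Compound 4 `CC(C)(C)c1ccc(CN(Cc2cccc(CCC(=O)O)c2)S(=O)(=O)c2ccc(Cl)cc2)cc1` has not been measured. It differs from compound 2 by chloro in place of hydrogen on an aromatic carbon. Among the measured compounds shown here, no step between two measured compounds shows what this change does in this assay, so the expectation rests on compound 2 alone. The step from compound 2 to compound 4 is expected to be small, a 1.4-fold lower number from compound 2 to compound 4 (0.14 log units; within the scatter), and may well fall within the scatter. Compound 4 is thus estimated at 200 nM, between 70 nM and 600 nM.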

Compound 4, half-maximal inhibitory concentration: > 3200 nM
Compound 4: only a limit was reported (the forecaster's own chance of this, stated with the estimate: 3%); at least 16-fold (1.20 log units) between middle value and limit.
By their numbers in this assay, from the lowest: compounds 2, 1 and 3 (each within the scatter of the next, the first and the last beyond it). At a limit, above all of these: compound 4.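

Compound 4 shows that this place on the phenylsulfonyl group, an aromatic carbon para to a large group, does not accept every change in this assay: a single chlorine atom in place of hydrogen gives an at least 11-fold higher number from compound 2 to compound 4 (1.06 log units; beyond the scatter). The number for compound 4 is a limit, so the full size of this step cannot be read: the limit of > 3200 nM in this assay, at which 1 of the 4 values shown sits.

The compounds shown leave open whether fluoro, methyl or methoxy at this place would give the same result. They also leave open whether chloro on another carbon of the phenyl ring would do so.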